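Swapping the aryl group on the amine of a diterpenoid lactone

This account rests on a few compounds, and the source may have more. Where it says the series, first, only, none or still open, it means among the compounds named here.

Three compounds share one core and differ only in the aromatic group attached to an amine nitrogen. Compound 1 `C=C1[C@@H](OC(C)=O)C[C@@H]2[C@](C)(CO[Si](C)(C)C(C)(C)C)[C@H](OC(C)=O)CC[C@@]2(C)[C@@H]1C[C@@H](Nc1ccccc1)C1=CCOC1=O` carries a phenyl there and in a functional assay on A549 cells (Homo sapiens) for cytotoxicity, read by sulforhodamine B assay (a higher number here means a weaker inhibitor, a lower number a stronger inhibitor), compound 1 gives 4500 nM. Compound 2 `C=C1[C@@H](OC(C)=O)C[C@@H]2[C@](C)(CO[Si](C)(C)C(C)(C)C)[C@H](OC(C)=O)CC[C@@]2(C)[C@@H]1C[C@@H](Nc1cccc(F)c1)C1=CCOC1=O` carries a 3-fluorophenyl and gives 4060 nM. Compound 3 `C=C1[C@@H](OC(C)=O)C[C@@H]2[C@](C)(CO[Si](C)(C)C(C)(C)C)[C@H](OC(C)=O)CC[C@@]2(C)[C@@H]1C[C@@H](Nc1cccc2ccccc12)C1=CCOC1=O` carries a naphthalen-1-yl and gives 4970 nM. Compound 3 stands alongside the other two: its gaps to compound 1 and to compound 2 are both within the usual scatter, so no order among the three can be read from these numbers.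

Compound 4 `C=C1[C@@H](OC(C)=O)C[C@@H]2[C@](C)(CO[Si](C)(C)C(C)(C)C)[C@H](OC(C)=O)CC[C@@]2(C)[C@@H]1C[C@@H](Nc1ccc(OC)c(OC)c1)C1=CCOC1=O` is the next step from compound 3: 3,4-dimethoxyphenyl in place of naphthalen-1-yl on an amine nitrogen.

The measured steps that bear on this all change the same aromatic group on the amine nitrogen. The step of a 1.1-fold higher number from compound 1 to compound 3 (0.04 log units; within the scatter), the step of a 1.2-fold higher number from compound 2 to compound 3 (0.09 log units; within the scatter) and the step of a 1.1-fold lower number from compound 1 to compound 2 (0.04 log units; within the scatter) were each within the scatter. Three different aryl groups, one of them a two-ring system, left the number essentially unchanged, which makes a further swap to 3,4-dimethoxyphenyl unlikely to move it beyond the scatter in either direction.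

Compound 4 is therefore expected to give about 4500 nM in this assay, with a range from 2000 nM to 10000 nM, an expected step of a 1.1-fold lower number from compound 3 to compound 4 (0.04 log units; within the scatter).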

Compound 4, half-maximal inhibitory concentration: 4870 nM
Estimate against measurement, compound 4: 1.1-fold (0.03 log units) below; the range from low to high includes it.
By their numbers in this assay, from the lowest: compounds 2, 1, 4 and 3 (each within the scatter of the next).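

Among the compounds shown here, compound 4 is the first in this set whose aryl group brings hydrogen-bond acceptors to the amine nitrogen: 3,4-dimethoxyphenyl has 2, and naphthalen-1-yl has none. It also replaces two aromatic rings with one, yet in this assay the outcome is a 1.0-fold lower number from compound 3 to compound 4 (0.01 log units; within the scatter), and the comparisons with the other two aryl groups give a 1.2-fold higher number from compound 2 to compound 4 (0.08 log units; within the scatter) and a 1.1-fold higher number from compound 1 to compound 4 (0.03 log units; within the scatter), so all four compounds remain indistinguishable and this position shows no response to any of these aryl changes. No measurement shown here accounts for this flat result.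

Every group shown on this nitrogen is an aromatic ring, so it remains open whether a saturated group such as cyclohexyl, or a phenyl ring carrying a carboxylic acid or an aminomethyl group, would shift the number beyond the scatter. Also open, as far as these compounds go, is whether changes elsewhere on the shared core, such as removing the tert-butyldimethylsilyl group to leave a free hydroxyl, would matter more than changes at this nitrogen.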